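The source may hold more compounds than are shown below. What is called first, only, known or untested is meant among the compounds shown, and "the series" means these compounds.

Measured so far:
compound 1, `O=C(Nc1ccc(Cl)c(-c2nnc3c(Cl)cccn23)c1)c1cccnc1`: > 100000 nM
compound 2, `O=C(Nc1ccc(Cl)c(-c2nnc3c(Cl)cccn23)c1)c1ccc(Cl)cc1Cl`: 78200 nM

In a functional assay on MCF7 cells (Homo sapiens) for antiproliferative activity, read by MTT assay, with a stated time of 72 h (a lower number here means a stronger inhibitor, a higher number a weaker inhibitor), compound 1 gives > 100000 nM, which is a limit of the assay rather than a number. Going by the values given here, compound 2 gives 78200 nM in this assay, the only number among the values shown. The step of an at least 1.2-fold lower number from compound 1 to compound 2 (0.10 log units; that floor lies within the scatter) is bounded by the limit of > 100000 nM in this assay, at which 1 of the 2 values shown sits, and so fixes neither its size nor its direction. Compound 3, `O=C(Nc1ccc(Cl)c(-c2nnc3c(Cl)cccn23)c1)c1ccon1`, differs from compound 2 in one place: 1,2-oxazol-3-yl in place of 2,4-dichlorophenyl on a carbonyl carbon. Among the compounds with values here, the only measured step touching this carbonyl carbon is an at least 1.2-fold lower number from compound 1 to compound 2 (0.10 log units; that floor lies within the scatter), where one heteroaromatic ring returned a limit and the 2,4-dichlorophenyl a number; no step beyond the scatter is recorded. Compound 3 is therefore expected to remain weak, with an estimated step of a 1.3-fold higher number from compound 2 to compound 3 (0.11 log units; within the scatter). Compound 3 is estimated at 100000 nM, between 40000 nM and 300000 nM, with a real chance that only a limit is returned.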

Compound 3, half-maximal inhibitory concentration: > 100000 nM
Compound 3: no number, only a limit (the forecaster's own chance of this, stated with the estimate: 55%); the middle value lies on the limit itself.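

In this assay, 1,2-oxazol-3-yl on the carbonyl carbon behaves as pyridin-3-yl did: compound 3 also returns a limit and not a number, so a second heteroaromatic ring, this time five-membered, gives no measurable value. Of the three groups shown at this place, only 2,4-dichlorophenyl yields a number, yet the step reads an at least 1.2-fold higher number from compound 2 to compound 3 (0.10 log units; that floor lies within the scatter), so the data do not separate these groups beyond the scatter. The step between the two compounds that return limits cannot be read, and the limit now holds most of the set: the limit of > 100000 nM in this assay, at which 2 of the 3 values shown sit.

From the compounds shown here alone, it stays open whether a plain phenyl or a 4-chlorophenyl on this carbonyl carbon would give a number. Going by these compounds, it is also open whether a ring carrying an amine or a carboxylic acid would move the value well away from that of compound 2.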